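The compounds below may be only part of what the source reports. "The series", "measured", "known", "first", "only" and "open" are said of these compounds alone.

Series around the shared core of compound 1 `c1cc(CN2CCN(CCCc3c[nH]c4ccc(-n5cnnc5)cc34)CC2)ccn1`, varied only in the group on the amine nitrogen in a ring. In an assay on CHO cells for displacement of a labelled ligand from 5-hydroxytryptamine receptor 1D (Homo sapiens) (a lower number here means a stronger inhibitor, a higher number a weaker inhibitor), compound 1 gives 0.6 nM. Compound 2 `c1c[nH]c(CN2CCN(CCCc3c[nH]c4ccc(-n5cnnc5)cc34)CC2)n1` gives 1.6 nM in this assay, a step of a 2.7-fold higher number from compound 1 to compound 2 (0.43 log units; beyond the scatter). Compound 3 `CC(=O)Nc1ccc(CN2CCN(CCCc3c[nH]c4ccc(-n5cnnc5)cc34)CC2)cc1` gives 2.5 nM in this assay, the highest of the three numbers; the step of a 4.2-fold higher number from compound 1 to compound 3 (0.62 log units; beyond the scatter) lies beyond the scatter, whereas a 1.6-fold higher number from compound 2 to compound 3 (0.19 log units; within the scatter) lies within it, so compound 3 and compound 2 cannot be ordered on these numbers.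

Compound 4 `c1cc2[nH]cc(CCCN3CCNCC3)c2cc1-n1cnnc1` is not yet measured. The change is hydrogen in place of 4-acetamidobenzyl on an amine nitrogen in a ring. Among the measured compounds shown here, none of the measured steps bears directly on this: each of them exchanges one arm for another, and the largest of those, a 4.2-fold higher number from compound 1 to compound 3 (0.62 log units; beyond the scatter), is modest. For the measured compounds named here, removing the arm altogether has no measured counterpart, so the expected step is larger than any of the exchanges and toward a higher number, with wide uncertainty. For compound 4 in this assay the estimate is 20 nM, with a range of 4 nM to 100 nM, which means an expected step of an 8.0-fold higher number from compound 3 to compound 4 (0.90 log units; beyond the scatter).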

Compound 4, half-maximal inhibitory concentration: 31 nM
For compound 4 the middle estimate is 1.6-fold (0.19 log units) below the measured one; measured number inside the range.
By their numbers in this assay, from the lowest: compound 1; then compounds 2 and 3 (each within the scatter of the next); then compound 4.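

In this assay, replacing the whole arm on the amine nitrogen in a ring with hydrogen gives a much larger change than any exchange of one arm for another: a 12-fold higher number from compound 3 to compound 4 (1.09 log units; beyond the scatter) and a 19-fold higher number from compound 2 to compound 4 (1.29 log units; beyond the scatter) and a 52-fold higher number from compound 1 to compound 4 (1.71 log units; beyond the scatter) are all large, whereas the exchanges were modest or within the scatter. All three arms, whether carrying pyridin-4-yl, 1H-imidazol-2-yl or 4-acetamidophenyl, give lower numbers than hydrogen does, so among these compounds the presence of an arm matters more than which of the three it is. Nothing available explains why the unsubstituted ring nitrogen gives the highest number.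

Going by these compounds, it remains open whether a methyl or an unsubstituted benzyl on this nitrogen would recover the lower numbers. On these data alone, the effect of a longer chain between the ring nitrogen and the aromatic ring also remains open.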